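Branching the linker: from compound 3 to compound 4

The source may report more compounds than this note shows. Statements on the series, on what has been measured and on what is new or still open speak of the compounds shown alone.

Measured so far:
compound 1 `CC1=C(CCC(=O)OCCCCOc2no[n+]([O-])c2S(=O)(=O)c2ccccc2)C(=O)c2c(O)cccc2C1=O`: 3330 nM
compound 2 `CC1=C(C(C)CC(=O)OCC(C)COc2no[n+]([O-])c2S(=O)(=O)c2ccccc2)C(=O)c2c(O)cccc2C1=O`: 3740 nM
compound 3 `CC1=C(CCC(=O)OCCCOc2no[n+]([O-])c2S(=O)(=O)c2ccccc2)C(=O)c2c(O)cccc2C1=O`: 6790 nM

Of the compounds shown here, three sharing one core have been tested in a functional assay on HepG2 cells (Homo sapiens) for inhibition, read by MTT assay, with a stated time of 72 h; a higher number here means a weaker inhibitor, a lower number a stronger inhibitor. Compound 1 gives 3330 nM, compound 2 gives 3740 nM, and compound 3 gives 6790 nM. Compound 3 carries the highest number of the three: against compound 2 the gap is within the scatter, while against compound 1 it lies beyond it, so compound 3 is a weaker inhibitor than compound 1 but cannot be separated from compound 2.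

Compound 4 `CC1=C(CCC(=O)OCC(C)COc2no[n+]([O-])c2S(=O)(=O)c2ccccc2)C(=O)c2c(O)cccc2C1=O` has not been measured. It differs from compound 3 in one place: methyl in place of hydrogen on a saturated chain carbon bound to two saturated chain carbons. Going by the values given here, no measured pair shows this change alone. Compound 2, which carries such a methyl on its linker among other differences, sits close to compound 3 in this assay, so the step of a 1.5-fold lower number from compound 3 to compound 4 (0.18 log units; within the scatter) is expected to be small and to stay within the scatter. Compound 4 is therefore estimated at 4500 nM, with a range from 2200 nM to 9000 nM.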

Compound 4, half-maximal inhibitory concentration: 6690 nM
For compound 4 the middle estimate is 1.5-fold (0.17 log units) below the measured one; low and high end bracket the measured number.
By their numbers in this assay, from the lowest: compounds 1, 2, 4 and 3 (each within the scatter of the next, the first and the last beyond it).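

In this assay, going by these compounds alone, methyl in place of hydrogen on a saturated chain carbon bound to two saturated chain carbons gives a 1.0-fold lower number from compound 3 to compound 4 (0.01 log units; within the scatter) and thus provides the first reading of this change on its own, with no effect the assay can resolve. Hydrogen in place of methyl on a saturated chain carbon bound to a double-bonded ring carbon and a saturated chain carbon gives a 1.8-fold higher number from compound 2 to compound 4 (0.25 log units; within the scatter) and likewise stays unresolved. In these two single pairs, then, a methyl at either position cannot be told apart from hydrogen.

As far as these compounds go, whether an ethyl group or an amine at either chain carbon would shift the number remains open. Nothing measured here accounts for these results.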